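This account rests on a few compounds, and the source may have more. Where it says the series, first, only, none or still open, it means among the compounds named here.

Measured so far in an assay on LtK cells with ATP-sensitive inward rectifier potassium channel 11 (Homo sapiens) as the target; a higher number here means that more compound is needed for the effect, a lower number that less compound is needed:
compound 1 `CCC(=O)Nc1c(C(O)(C(F)(F)F)C(F)(F)F)ccc2ccccc12`: 15 nM
compound 2 `CC(C)CCC(=O)Nc1c(C(O)(C(F)(F)F)C(F)(F)F)ccc2ccccc12`: 49 nM
compound 3 `COCC(=O)Nc1c(C(O)(C(F)(F)F)C(F)(F)F)ccc2ccccc12`: 213 nM

Compound 3 stands highest of the three numbers, with a 14-fold higher number from compound 1 to compound 3 (1.15 log units; beyond the scatter) and a 4.3-fold higher number from compound 2 to compound 3 (0.64 log units; beyond the scatter) both beyond the scatter. Compound 4 `O=C(Nc1c(C(O)(C(F)(F)F)C(F)(F)F)ccc2ccccc12)c1ccc(Cl)cc1` moves to an aromatic acyl group: 4-chlorophenyl in place of methoxymethyl on a carbonyl carbon. Only the two steps that exchanged the methoxymethyl bear on this change, and both went the same way: the methoxymethyl compound gave the highest number, the two hydrocarbon acyl groups gave lower numbers, by a 4.3-fold higher number from compound 2 to compound 3 (0.64 log units; beyond the scatter) and a 14-fold higher number from compound 1 to compound 3 (1.15 log units; beyond the scatter). The 4-chlorophenyl is likewise a group without a hydrogen-bond acceptor, so a lower number is expected, roughly a 4.3-fold lower number from compound 3 to compound 4 (0.63 log units; beyond the scatter). The size is uncertain; no aromatic acyl group has been measured. Compound 4 is therefore estimated at 50 nM in this assay, range 10 nM to 250 nM.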

Compound 4, half-maximal effective concentration: 570 nM
Beside the measured number, compound 4's estimate is 11-fold (1.06 log units) below it; the measured number lies above the stated range.
By their numbers in this assay, from the lowest: compound 1; then compound 2; then compound 3; then compound 4.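

In this assay, replacing methoxymethyl with 4-chlorophenyl on the carbonyl carbon gives a 2.7-fold higher number from compound 3 to compound 4 (0.43 log units; beyond the scatter) and so does not lower the number, which shows that a group with no hydrogen-bond acceptor is not enough to do so at this position. The aromatic acyl group also stands well behind the chain acyl groups, with a 12-fold higher number from compound 2 to compound 4 (1.07 log units; beyond the scatter) and a 38-fold higher number from compound 1 to compound 4 (1.58 log units; beyond the scatter), leaving ethyl with the lowest number of the four. No available evidence accounts for this order.

On these data alone, it remains open whether the rise follows the aromatic ring or the chlorine. Unsubstituted phenyl and cyclohexyl on the same carbonyl carbon would separate the two.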